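From 4-chlorophenyl to 3-chlorophenyl on a shared core

The source may hold more compounds than are shown below. What is called first, only, known or untested is meant among the compounds shown, and "the series" means these compounds.

In a functional assay on K562 cells (Homo sapiens) for inhibition, read by fluorescence, with a stated time of 72 h (a higher number here means a weaker inhibitor of growth, a lower number a stronger inhibitor of growth), compound 3 `CCCCn1cnc2c(Nc3ccc(Cl)cc3)nc(N[C@H]3CC[C@H](N)CC3)nc21` gives 2700 nM. Compound 1 `COc1ccc(Cn2cnc3c(Nc4cccc(Cl)c4)nc(N[C@H]4CC[C@H](N)CC4)nc32)cc1` gives 2800 nM and compound 2 `CC(C)=CCn1cnc2c(Nc3cccc(Cl)c3)nc(N[C@H]3CC[C@H](N)CC3)nc21` gives 3500 nM, and all three values lie within the scatter of one another. Compound 4 `CCCCn1cnc2c(Nc3cccc(Cl)c3)nc(N[C@H]3CC[C@H](N)CC3)nc21` differs from compound 3 at one place, on a nitrogen on an aromatic ring: 3-chlorophenyl in place of 4-chlorophenyl on a nitrogen on an aromatic ring. Within the data shown here, no measured step tests this change directly. Among the measured compounds shown here, the only step available, a 1.3-fold higher number from compound 1 to compound 2 (0.10 log units; within the scatter), lies within the scatter and concerns another place, a saturated chain carbon bound to an aromatic nitrogen. It bears on the question only indirectly, since both of its compounds already carry 3-chlorophenyl and show values close to that of compound 3. Nothing beyond the scatter is therefore expected in this assay. The expected step, a 1.0-fold higher number from compound 3 to compound 4 (0.02 log units; within the scatter), is an estimate that stays within the scatter. Compound 4 is estimated at 2800 nM, with an expected range from 1200 nM to 6500 nM.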

Compound 4, concentration for 50% growth inhibition: 2000 nM
For compound 4 the middle estimate is 1.4-fold (0.15 log units) above the measured one, within the range that was stated.
By their numbers in this assay, from the lowest: compounds 4, 3, 1 and 2 (each within the scatter of the next).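

In this assay, 3-chlorophenyl in place of 4-chlorophenyl on a nitrogen on an aromatic ring gives a 1.4-fold lower number from compound 3 to compound 4 (0.13 log units; within the scatter), so the first direct test of this change shows no effect beyond the scatter. With 3-chlorophenyl held in place, the group on a saturated chain carbon bound to an aromatic nitrogen also gives no step beyond the scatter: propyl in place of 2-methylprop-1-en-1-yl gives a 1.8-fold lower number from compound 2 to compound 4 (0.24 log units; within the scatter), and propyl in place of 4-methoxyphenyl gives a 1.4-fold lower number from compound 1 to compound 4 (0.15 log units; within the scatter). No measurement offered here accounts for these results.

On these data alone, whether a phenyl without chlorine or a bromophenyl on that nitrogen would give a step beyond the scatter remains open. The same is true of a carboxylic acid or a longer chain in place of propyl.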